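This account rests on a few compounds, and the source may have more. Where it says the series, first, only, none or still open, it means among the compounds named here.

Measured in a functional assay on WiDr cells (Homo sapiens) for cytotoxicity, read by MTT assay; on this read-out higher numbers stand for weaker inhibition and lower numbers for stronger inhibition:
- Compound 1 `CC(=O)O[C@@H]1/C(C(C)C)=C\C=C(/C)CC/C=C(\C)CC[C@@H]2O[C@@]2(C)[C@H]1OC(C)=O`: 13.8 ug/mL
- Compound 2 `C=C1CC[C@@H]2CC[C@H](OC(=O)C/C(C)=C/[C@@H](OC(=O)c3ccccc3)C1)C(=O)C2(C)C`: > 20 ug/mL, a limit
- Compound 3 `C=C1CC[C@@H]2CC[C@H](OC(=O)C/C(C)=C/[C@@H](OC(C)=O)C1)C(=O)C2(C)C`: > 20 ug/mL, a limit

Compound 3 has no number on this read-out, only the limit > 20 ug/mL. It shares this position with compound 2, and together they stand at the limit of > 20 ug/mL in this assay, at which 2 of the 3 values shown sit. Compound 1, built on a different core, is the only one of the three with a measured number.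

Compound 4 `C=C1CC[C@@H]2CC[C@H](OC(=O)C/C(C)=C/[C@@H](OC(=O)c3ccc(Cl)cc3)C1)C(=O)C2(C)C` keeps the core of compound 3 and changes one group, with 4-chlorophenyl in place of methyl on a carbonyl carbon.

Within the data shown here, one measured step bears on this change, since it concerns the same carbonyl carbon: a step that the two limits leave unreadable from compound 2 to compound 3. Its size cannot be read. It shows only that neither the phenyl of compound 2 nor the methyl of compound 3 gave a number in this assay. With so little to go on, no clear step in either direction is expected, and another limit is quite possible. The expected change is a number no higher from compound 3 to compound 4 (the limit leaves the size open). For compound 4 the estimated value is 20 ug/mL, with an expected range of 10 ug/mL to 40 ug/mL.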

Compound 4, half-maximal inhibitory concentration: > 20 ug/mL
Compound 4: no number, only a limit (the forecaster's own chance of this, stated with the estimate: 60%); the middle value lies on the limit itself.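

In this assay compound 4 gives > 20 ug/mL, which is a limit and not a number. Its steps from compound 2 and compound 3 therefore cannot be read. The compounds shown leave open whether the group on the carbonyl carbon changes the read-out at all, since compound 2, compound 3 and compound 4 share one position: the limit of > 20 ug/mL in this assay, at which 3 of the 4 values shown sit.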